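The source may report more compounds than this note shows. Statements on the series, on what has been measured and on what is new or still open speak of the compounds shown alone.

Three compounds of the series have been run in an ADME assay on MCF7 cells (Homo sapiens) for cytotoxicity, with a stated time of 72 h (a higher number here means a weaker inhibitor, a lower number a stronger inhibitor), and all three returned only limits. Compound 1 `COc1ccc(CNc2ncnc3c2ncn3C2CCCCO2)c(OC)c1` sits at a limit, > 25000 nM, so no number is available for it. Compound 2 `COc1cc(CNc2ncnc3c2ncn3C2CCCCO2)cc(OC)c1` likewise stops at a limit, > 100000 nM, and compound 3 `COc1cc(OC)c(OC)cc1CNc1ncnc2c1ncn2C1CCCCO1` also gives a limit, > 100000 nM. How compound 1 and compound 2 differ is not broken down here. From compound 1 to compound 3 the change is methoxy in place of hydrogen on an aromatic carbon, and the step that the two limits leave unreadable from compound 1 to compound 3 cannot be read because both ends are limits; what the assay offers instead is the limit of > 100000 nM in this assay, at which 2 of the 3 values shown sit, and (the limit of > 25000 nM in this assay, at which 1 of the 3 values shown sits), which say only that none of the three reaches a measurable concentration.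

Compound 4 `COc1cc(CNc2ncnc3c2ncn3C2CCCCO2)cc(OC)c1OC` has not yet been measured. It differs from compound 2 by methoxy in place of hydrogen on an aromatic carbon, the same kind of change as from compound 1 to compound 3, though the surroundings differ: in compound 4 the new group stands ortho to two methoxy groups and para to a large group, whereas in compound 3 it stands ortho to a methoxy group, meta to a large group and para to a methoxy group. Since the earlier step of this kind was unreadable, and since compound 2 gives > 100000 nM as a limit, the expectation for compound 4 is a step that the limit leaves unreadable from compound 2 to compound 4 in this assay, i.e. no measurable change. Compound 4 is therefore estimated at 150000 nM, with a range from 50000 nM to 500000 nM, and most likely the assay will again report only a limit.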

Compound 4, half-maximal inhibitory concentration: > 100000 nM
Compound 4: no number, only a limit; the forecaster's own chance of this, stated with the estimate: 90%; the middle value lies beyond the limit too.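

Compound 4 and compound 2 both return only limits in this assay, so no step can be read between them, and the one result available is a shared limit: the limit of > 100000 nM in this assay, at which 3 of the 4 values shown sit.

The compounds shown leave open whether methoxy in place of hydrogen on an aromatic carbon changes the read-out in this assay at all, and where any of the four compounds would give an actual number.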